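Swapping the phenoxy link back to a fluorinated benzyl chain

The source may hold more compounds than are shown below. What is called first, only, known or untested is meant among the compounds shown, and "the series" means these compounds.

The measured compounds, all in a functional assay on CHO cells for antagonist activity at Orexin receptor type 2 (Homo sapiens), read by FLIPR and calcium flux; on this read-out higher numbers stand for weaker inhibition and lower numbers for stronger inhibition:
compound 1 `CCc1nc(Cl)c2n1CCN([C@@H](C(=O)NC)c1ccccc1)[C@H]2CCc1cccc(C(F)(F)F)c1` gives 10 nM;
compound 2 `CCc1nc(Cl)c2n1CCN([C@@H](C(=O)NC)c1ccccc1)[C@H]2COc1ccc(C(F)(F)F)cc1` gives 9 nM;
compound 3 `CCc1nc(Cl)c2n1CCN([C@@H](C(=O)NC)c1ccccc1)[C@H]2COc1cccc(C(F)(F)F)c1` gives 4 nM.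

Compound 3 holds the lowest number of the three, as the steps of a 2.3-fold lower number from compound 2 to compound 3 (0.35 log units; beyond the scatter) and a 2.5-fold lower number from compound 1 to compound 3 (0.40 log units; beyond the scatter) show. Compound 4 `CCc1nc(Cl)c2n1CCN([C@@H](C(=O)NC)c1ccccc1)[C@H]2CCc1ccc(F)c(F)c1F` differs from it by 2,3,4-trifluorobenzyl in place of 3-(trifluoromethyl)phenoxy on a saturated chain carbon bound to a saturated ring carbon. Within the data shown here, one measured step bears on this change: a 2.5-fold lower number from compound 1 to compound 3 (0.40 log units; beyond the scatter), where a benzyl chain became a phenoxy one. Among the measured compounds shown here, compound 4 reverses that exchange, and it also alters the fluorine pattern on the ring, for which no measured step exists. The expected outcome is a modest rise in number, roughly undoing that step: a 3.0-fold higher number from compound 3 to compound 4 (0.48 log units; beyond the scatter) is estimated. Compound 4 is therefore expected to give 12 nM, within a range from 4 nM to 35 nM.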

Compound 4, half-maximal inhibitory concentration: 5 nM
For compound 4 the middle estimate is 2.4-fold (0.38 log units) above the measured one, and the stated range covers the measured number.
By their numbers in this assay, from the lowest: compounds 3, 4, 2 and 1 (each within the scatter of the next, the first and the last beyond it).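

The step of a 1.3-fold higher number from compound 3 to compound 4 (0.10 log units; within the scatter) shows that this position accepts 2,3,4-trifluorobenzyl in place of 3-(trifluoromethyl)phenoxy, so a low number here does not depend on the phenoxy oxygen. The other two steps, a 1.8-fold lower number from compound 2 to compound 4 (0.26 log units; within the scatter) and a 2.0-fold lower number from compound 1 to compound 4 (0.30 log units; within the scatter), also lie within the scatter, so compound 4 cannot be told apart from any earlier compound. Nothing available gives a reason for this result.

Going by these compounds, compound 4 changes both the link and the fluorine pattern, so their separate contributions remain unknown. On these data alone, how an amine, a carboxylic acid or a longer chain would fare at this position also remains open.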